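A few compounds are considered here, and "the series" means these few. Any claim that something is new, unique, unknown or untested is made for them only; others in the source may bear on it.

Measured compounds in a functional assay on SiHa cells (Homo sapiens) for cytotoxicity, read by MTT assay, with a stated time of 48 h; a lower number here means a stronger inhibitor, a higher number a weaker inhibitor:
compound 1, `CCCCCCCCCCCCCCNC(=O)[C@@H](NC(=O)c1cccs1)[C@@H](C)O`: 63000 nM
compound 2, `CCCCCCCCCCCCCCNC(=O)[C@@H](NC(=O)c1cc2ccccc2o1)[C@@H](C)O`: 14200 nM

Compound 2 holds the lower of the two numbers; the step of a 4.4-fold lower number from compound 1 to compound 2 (0.65 log units; beyond the scatter) separates it from compound 1. Compound 3, `CCCCCCCCCCCCCCNC(=O)[C@@H](NS(=O)(=O)c1ccc(C)cc1)[C@@H](C)O`, carries the change ((4-methylphenyl)sulfonyl in place of (1-benzofuran-2-yl)carbonyl on an amine nitrogen). Among the measured compounds shown here, only one measured step bears on this position, a 4.4-fold lower number from compound 1 to compound 2 (0.65 log units; beyond the scatter), and it exchanged one aromatic carbonyl for another rather than a carbonyl for a sulfonyl, so it gives weak guidance. For the measured compounds named here, with no closer precedent, the number is expected to drift upward modestly or stay within the scatter, and compound 3 is estimated at 25000 nM (range 8000 nM to 80000 nM), an expected step of a 1.8-fold higher number from compound 2 to compound 3 (0.25 log units; within the scatter).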

Compound 3, half-maximal inhibitory concentration: 19200 nM
Compound 3: middle estimate off by 1.3-fold (0.11 log units), on the high side; the range from low to high includes it.
By their numbers in this assay, from the lowest: compounds 2 and 3 (each within the scatter of the next); then compound 1.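

On the amine nitrogen, a sulfonyl group can take the place of a carbonyl without loss in this assay: replacing (1-benzofuran-2-yl)carbonyl with (4-methylphenyl)sulfonyl leaves the number within the scatter (a 1.4-fold higher number from compound 2 to compound 3 (0.13 log units; within the scatter)), and replacing (thiophen-2-yl)carbonyl with it gives a modest gain (a 3.3-fold lower number from compound 1 to compound 3 (0.52 log units; beyond the scatter)). Thus, this position accepts a single six-membered aromatic ring when it is carried on a sulfonyl. No measurement at hand explains either step. Both steps change the aromatic ring along with the linking group, so the sulfonyl's own contribution remains unseparated. From the compounds shown here alone, a benzoyl or methanesulfonyl group on this nitrogen, or a shorter chain, remains open.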